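Compound 4: expected tolerance from the three measured analogues

The compounds below may be only part of what the source reports. "The series", "measured", "known", "first", "only" and "open" are said of these compounds alone.

The three measured compounds share one core and differ only in the substituent attached to it. Compound 1 `CCNC(=O)NC1=CS(=O)(=O)O[C@@]12[C@@H](CO[Si](C)(C)C(C)(C)C)O[C@@H](n1cc(C)c(=O)n(C)c1=O)[C@@H]2O[Si](C)(C)C(C)(C)C` gives 10000 nM in a functional assay on HEL cells (Homo sapiens); a higher number here means that more compound is tolerated, a lower number that less compound is tolerated. Compound 2 `COC(=O)CC(=O)NC1=CS(=O)(=O)O[C@@]12[C@@H](CO[Si](C)(C)C(C)(C)C)O[C@@H](n1cc(C)c(=O)n(C)c1=O)[C@@H]2O[Si](C)(C)C(C)(C)C` gives 29000 nM in this assay. Compound 3 `CCOC(=O)CNC(=O)NC1=CS(=O)(=O)O[C@@]12[C@@H](CO[Si](C)(C)C(C)(C)C)O[C@@H](n1cc(C)c(=O)n(C)c1=O)[C@@H]2O[Si](C)(C)C(C)(C)C` gives 13000 nM in this assay. Compound 3 thus holds the second highest of the three numbers: its nearest neighbour is compound 1, since a 1.3-fold higher number from compound 1 to compound 3 (0.11 log units; within the scatter), and its furthest is compound 2, since a 2.2-fold lower number from compound 2 to compound 3 (0.35 log units; beyond the scatter). The remaining measured step is also modest: a 2.9-fold higher number from compound 1 to compound 2 (0.46 log units; beyond the scatter).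

Compound 4 `C=C(C)C(=O)NC(=O)NC1=CS(=O)(=O)O[C@@]12[C@@H](CO[Si](C)(C)C(C)(C)C)O[C@@H](n1cc(C)c(=O)n(C)c1=O)[C@@H]2O[Si](C)(C)C(C)(C)C` is not yet measured in this assay. It differs from compound 3 in one place: (1-methylethenyl)carbonyl in place of (ethoxycarbonyl)methyl on an amide-type nitrogen. Going by the values given here, no measured step reproduces this exchange; all three measured steps alter the same substituent and none of them moves this assay by more than a modest amount, with one of them staying within the scatter. On that basis a small step is expected for compound 4, in either direction or none beyond the scatter, with the step from compound 2 to compound 3 as the upper bound of what has been seen. The expected step is a 1.1-fold lower number from compound 3 to compound 4 (0.03 log units; within the scatter). Compound 4 is estimated at 12000 nM, with a range from 5000 nM to 30000 nM.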

Compound 4, half-maximal cytotoxic concentration: 1200 nM
The estimate for compound 4 lay 10-fold (1.00 log units) above the measured number; measured number outside the range, below it.
By their numbers in this assay, from the lowest: compound 4; then compounds 1 and 3 (each within the scatter of the next); then compound 2.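

In this assay, going by these compounds alone, this position proves far more responsive than the earlier compounds suggested: (1-methylethenyl)carbonyl in place of (ethoxycarbonyl)methyl on the amide-type nitrogen gives an 11-fold lower number from compound 3 to compound 4 (1.03 log units; beyond the scatter) and stands out from the earlier steps. The other two steps run the same way, with a 24-fold lower number from compound 2 to compound 4 (1.38 log units; beyond the scatter) and with an 8.3-fold lower number from compound 1 to compound 4 (0.92 log units; beyond the scatter) when the group replaces ethyl, so compound 4 sits alone at the low end of the series. Among the substituents shown, only this one, which places a carbonyl directly on that nitrogen and carries two double bonds outside aromatic rings, brings the number down this far, and no measured evidence accounts for the fall.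

The compounds shown leave open whether the fall goes with the carbonyl on the nitrogen or with the 1-methylethenyl part, a question that a saturated 2-methylpropanoyl group or a plain acetyl group at the same place would settle. Also open, as far as these compounds go, is how a free carboxylic acid in place of the ethyl ester of (ethoxycarbonyl)methyl, or a longer unsaturated acyl chain, would read in this assay on the shared core.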